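This account rests on a few compounds, and the source may have more. Where it says the series, first, only, none or still open, it means among the compounds named here.

Compound 1 `CC1=CC[C@H]2[C@@H]1CC=C(C)[C@@H](CCC1=C(C)CC[C@@H]3OC(C)(C)[C@@H](O)CC[C@@]13C)C2(C)C` gives > 50000 nM in a functional assay on MDA-MB-231 cells (Homo sapiens) for antiproliferative activity, read by MTT assay, with a stated time of 72 h (a lower number here means a stronger inhibitor, a higher number a weaker inhibitor), which is a limit of the assay rather than a number (the limit of > 50000 nM in this assay, at which 1 of the 2 values shown sits). Among the measured compounds shown here, compound 2 `CC1=CC[C@H]2[C@H](CC[C@]2(C)O)C(C)(C)[C@@H]1CC[C@H]1[C@]2(C)CC[C@H](OC(=O)c3ccc(Cl)cc3)C(C)(C)O[C@H]2CC[C@@]1(C)O` gives 10300 nM in this assay, the only number among the two values shown, so compound 2 stands as the sole measured point. Compound 3 `CC1=CC[C@H]2[C@H](CC[C@]2(C)O)C(C)(C)[C@@H]1CC[C@H]1[C@]2(C)CC[C@H](OC(=O)c3ccc(C(F)(F)F)c(F)c3)C(C)(C)O[C@H]2CC[C@@]1(C)O` differs from compound 2 by 3-fluoro-4-(trifluoromethyl)phenyl in place of 4-chlorophenyl on a carbonyl carbon. For the measured compounds named here, no measured step covers a change of this kind, so its size is open; a step no larger than the usual scatter is expected, in no settled direction. Compound 3 is estimated at 7000 nM, between 2500 nM and 20000 nM. The expected step is a 1.5-fold lower number from compound 2 to compound 3 (0.17 log units; within the scatter).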

Compound 3, half-maximal inhibitory concentration: 22200 nM
Beside the measured number, compound 3's estimate is 3.2-fold (0.50 log units) below it, outside the stated range (above it).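

In this assay, among the compounds shown here, the group on the carbonyl carbon gives the first readable step: a 2.2-fold higher number from compound 2 to compound 3 (0.33 log units; beyond the scatter). The number at this position therefore responds to the aryl group, and 3-fluoro-4-(trifluoromethyl)phenyl gives a weaker inhibitor than 4-chlorophenyl. Nothing shown accounts for this step.

The compounds shown leave open whether an aryl ring carrying an amine or a carboxylic acid, or a longer alkyl chain in place of the ring, would give a lower number. For the compounds shown here, with only two aryl groups compared, which part of the change carries the step also stays open.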